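Phenyl for Methyl on a Ring Nitrogen

This account rests on a few compounds, and the source may have more. Where it says the series, first, only, none or still open, it means among the compounds named here.

Measured so far:
compound 1, `COC(=O)c1c(O)c2ccccc2n(C)c1=O`, 7.4%
compound 2, `COC(=O)c1c(O)c2ccccc2n(-c2ccccc2)c1=O`, 9.1%
compound 3, `Cn1c(=O)c(C(=O)NCCCCCCN)c(O)c2ccccc21`, 8.3%

All three compounds were tested in a functional assay, with a stated time of 60 min, tested at 0.1 mM; a lower number here means a weaker effect, a higher number a stronger effect of the compound at the concentration tested. Compound 1 and compound 2 differ in one place: phenyl in place of methyl on an aromatic nitrogen. This change gave a number 1.7 percentage points higher from compound 1 to compound 2 (within the scatter), so the two numbers cannot be told apart. Compound 3 sits on a different core, and the difference between the core of compound 1 and the core of compound 3 is not broken down here.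

Compound 4, `NCCCCCCNC(=O)c1c(O)c2ccccc2n(-c2ccccc2)c1=O`, has not yet been measured in this assay. It differs from compound 3 in the same kind of change: phenyl in place of methyl on an aromatic nitrogen. The surroundings are not identical word for word: in compound 1 the nitrogen is meta to a methoxycarbonyl group (4 heavy atoms), while in compound 3 it is meta to a large group.

Among the compounds with values here, because the only earlier example of this change gave a number 1.7 percentage points higher from compound 1 to compound 2 (within the scatter), a small step is expected again, a number 1.2 percentage points higher from compound 3 to compound 4 (within the scatter). Compound 4 is therefore estimated at 9.5%, most likely between 2% and 18%.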

Compound 4, a percentage reported as activity, at one concentration (the size of the read-out at that concentration, not a potency): 17.5%
Beside the measured number, compound 4's estimate is 8 percentage points below it; the measured number falls inside the stated range.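

In this assay, phenyl in place of methyl on an aromatic nitrogen cannot be said to behave differently on the two cores: the same change on two cores in this assay, a number 1.7 percentage points higher (within the scatter) from compound 1 to compound 2 and a number 9.2 percentage points higher (within the scatter) from compound 3 to compound 4, 7.5 percentage points apart, within the scatter of two such steps. Taken alone, the new step is a number 9.2 percentage points higher from compound 3 to compound 4 (within the scatter), and (6-aminohexyl)amino in place of methoxy on a carbonyl carbon gives a number 8.4 percentage points higher from compound 2 to compound 4 (within the scatter), so neither step can be told apart from the ordinary spread of repeated measurements. The change therefore shows no detectable dependence on the core, but this does not prove that it carries over equally, or that it has a real effect on either core, and two pairs say nothing about other cores.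

From the compounds shown here alone, it remains open whether a shorter or longer chain than 6-aminohexyl, or a carboxylic acid in place of the methoxycarbonyl group, would give a step beyond the scatter. Also open, going by these compounds, is whether a benzyl group on the aromatic nitrogen would do so.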